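A Benzyl(methyl)amino Variant of a Non-Toxic Nucleoside

This account rests on a few compounds, and the source may have more. Where it says the series, first, only, none or still open, it means among the compounds named here.

Compound 2 `OC[C@H]1O[C@@H](n2cnc3c(CSCc4ccccc4)ncnc32)[C@H](O)[C@@H]1O` was tested in a functional assay on Huh-7 cells (Homo sapiens) for cytotoxicity, read by MTT assay, with a stated time of 3 days; on this read-out higher numbers stand for lower toxicity in this test and lower numbers for higher toxicity in this test. In this assay compound 2 gives > 100000 nM, which is a limit of the assay rather than a number. Compound 1 `[N-]=[N+]=NCc1ncnc2c1ncn2[C@@H]1O[C@H](CO)[C@@H](O)[C@H]1O` also sits at a limit: in this assay compound 1 gives > 250000 nM. Within the data shown here, the only measured step, a step that the two limits leave unreadable from compound 1 to compound 2, cannot be read because both ends are limits the limit of > 100000 nM in this assay, at which 1 of the 2 values shown sits, and (the limit of > 250000 nM in this assay, at which 1 of the 2 values shown sits). Compound 3 `CN(Cc1ccccc1)Cc1ncnc2c1ncn2[C@@H]1O[C@H](CO)[C@@H](O)[C@H]1O` has not yet been measured; it differs from compound 2 by benzyl(methyl)amino in place of benzylsulfanyl on a saturated chain carbon bound to an aromatic carbon. Among the measured compounds shown here, no measured step describes a change of this kind, and the two limits give no direction for it. The expectation is that compound 3 stays at or near the limit, with a step that the limit leaves unreadable from compound 2 to compound 3 expected to lie within the scatter. The estimated value of compound 3 is 150000 nM, with a range from 30000 nM to 500000 nM.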

Compound 3, half-maximal cytotoxic concentration: 9000 nM
Compound 3: the middle estimate sits 17-fold (1.22 log units) above what was measured; measured number below the stated range.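

At this saturated chain carbon bound to an aromatic carbon, the choice of group can move the result in this assay: benzyl(methyl)amino in place of benzylsulfanyl gives an at least 11-fold lower number from compound 2 to compound 3 (1.04 log units; beyond the scatter), and benzyl(methyl)amino in place of azido gives an at least 27-fold lower number from compound 1 to compound 3 (1.44 log units; beyond the scatter). Benzylsulfanyl and benzyl(methyl)amino each hold one six-membered aromatic ring of carbon only, so that ring alone does not decide the outcome. The full size of the first step stays unknown, because compound 2 stands at a limit of the assay: the limit of > 100000 nM in this assay, at which 1 of the 3 values shown sits.

The compounds shown leave open whether the change rests on the nitrogen, on its methyl or on the benzyl attached with them. Benzylamino, which lacks the methyl, and dimethylamino, which lacks the benzyl, would help separate these parts.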